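The source may report more compounds than this note shows. Statements on the series, on what has been measured and on what is new or still open speak of the compounds shown alone.

Compound 1 `C/N=C(\N)Nc1nnc(-c2ccccc2C(F)(F)F)s1` gives 49 mg/kg in a functional assay on the whole organism (Hindlimb) for inhibition, with Mus musculus as the target, in the maximal electroshock model, with a stated time of 1 h; on this read-out higher numbers stand for an effect only at larger amounts of compound and lower numbers for an effect already at smaller amounts. Compound 2 `CN(C1=NCCN1)c1nnc(-c2ccccc2C(F)(F)F)s1` reaches only a limit of this assay, > 100 mg/kg. The step of an at least 2.0-fold higher number from compound 1 to compound 2 (0.30 log units; that floor lies within the scatter) is therefore a floor, fixed by the limit of > 100 mg/kg in this assay, at which 1 of the 2 values shown sits. Compound 3 `CN(C1=NC(C)(C)CN1)c1nnc(-c2ccccc2C(F)(F)F)s1` differs from compound 2 by a group of 7 heavy atoms (5 carbon, 2 nitrogen; one five-membered non-aromatic ring with 2 hetero atoms) in place of a group of 5 heavy atoms (3 carbon, 2 nitrogen; one five-membered non-aromatic ring with 2 hetero atoms), on a nitrogen on an aromatic ring. Among the compounds with values here, the only measured step, an at least 2.0-fold higher number from compound 1 to compound 2 (0.30 log units; that floor lies within the scatter), rests on a limit, and no measured step touches that ring; compound 3 is expected to show no step beyond the scatter in this assay. The estimate for compound 3 is 150 mg/kg, within 50 mg/kg to 500 mg/kg, an expected step that the limit leaves unreadable from compound 2 to compound 3.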

Compound 3, dose for half-maximal effect: > 100 mg/kg
Compound 3: no number, only a limit (the forecaster's own chance of this, stated with the estimate: 65%); the middle value does not contradict the limit.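

Compound 2 and compound 3 both stand at a limit of this assay, so no step can be read between them: the limit of > 100 mg/kg in this assay, at which 2 of the 3 values shown sit.

The compounds shown leave open how the ring of 7 heavy atoms compares with the ring of 5 heavy atoms in this read-out.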